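Swapping a Nitro Group for Two Hydroxyls

The source may hold more compounds than are shown below. What is called first, only, known or untested is meant among the compounds shown, and "the series" means these compounds.

The measured compounds:
compound 1, `COc1ccc(/C=N/NC(=O)CCc2nc3ccccc3c(=O)[nH]2)cc1`, with 75000000 nM
compound 2, `O=C(CCCc1nc2ccccc2c(=O)[nH]1)N/N=C/c1ccc([N+](=O)[O-])cc1`, with 270000000 nM
compound 3, `COc1cc(/C=N/NC(=O)CCc2nc3ccccc3c(=O)[nH]2)cc(OC)c1OC`, with 55000000 nM

These three share a core and differ in the aromatic ring attached through the double-bonded nitrogen. In a physicochemical assay, read by spectrophotometry, with a stated time of 6 min (on this read-out lower numbers stand for stronger inhibition and higher numbers for weaker inhibition), compound 2 gives 270000000 nM, the highest of the three numbers, which here means the weakest inhibition; compound 1 and compound 3 both sit clearly lower, beyond the usual scatter.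

Compound 4, `O=C(CCCc1nc2ccccc2c(=O)[nH]1)N/N=C/c1ccc(O)c(O)c1`, has not been measured. It differs from compound 2 in one place: 3,4-dihydroxyphenyl in place of 4-nitrophenyl on a carbon with a double bond to nitrogen.

Within the data shown here, no step between measured compounds bears directly on this change, so the expectation rests on the spread of the three values. Compound 2 stands highest, and the two ring variants that replace the 4-nitrophenyl both give lower numbers, so a move to a lower number, beyond the scatter, is expected in this assay for the step of an 18-fold lower number from compound 2 to compound 4 (1.26 log units; beyond the scatter). Compound 4 is therefore estimated at 15000000 nM, within a range from 1000000 nM to 100000000 nM.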

Compound 4, half-maximal inhibitory concentration: 50000000 nM
The estimate for compound 4 lay 3.3-fold (0.52 log units) below the measured number; the measured number falls inside the stated range.
By their numbers in this assay, from the lowest: compounds 4, 3 and 1 (each within the scatter of the next); then compound 2.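

Among these compounds, the change gives a 5.4-fold lower number from compound 2 to compound 4 (0.73 log units; beyond the scatter) in this assay and is the first step here to isolate the ring on a carbon with a double bond to nitrogen, since compound 1 and compound 3 each differ from compound 2 in more than one place. It shows that 4-nitrophenyl can be replaced at this position by 3,4-dihydroxyphenyl with a fall in the number beyond the scatter, which on this read-out means stronger inhibition. No measurement here explains this fall, so it cannot be assigned to gaining the hydroxyls or to losing the nitro group.

From the compounds shown here alone, it remains open whether both hydroxyls are needed, or whether a phenyl ring carrying only one would give a similar number. Also open, going by these compounds, is how a phenyl ring carrying an amine or a carboxylic acid would compare at this position.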